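A few compounds are considered here, and "the series" means these few. Any claim that something is new, unique, unknown or untested is made for them only; others in the source may bear on it.

Measured so far:
- Compound 1, `COc1cc(C[C@@H]2C(=O)OC[C@H]2[C@@H](O[C@@H]2O[C@H](CO)[C@@H](O)[C@H](O)[C@H]2O)c2ccc(O)c(OC)c2)ccc1O`: > 10000 nM
- Compound 2, `COc1cc(C[C@@H]2C(=O)OC[C@H]2[C@@H](O)c2ccc(O[C@@H]3O[C@H](CO)[C@@H](O)[C@H](O)[C@H]3O)c(OC)c2)ccc1O`: > 10000 nM

Both values come from a functional assay on SK-MEL-2 cells (Homo sapiens) for cytotoxicity, read by sulforhodamine B assay, with a stated time of 48 h; a lower number here means a stronger inhibitor, a higher number a weaker inhibitor. For compound 1 the value is a limit of the assay and not a number. For compound 2 the value is likewise a limit and not a number. Compound 2 therefore stands at the limit of > 10000 nM in this assay, at which 2 of the 2 values shown sit, and nothing in the data places it above or below compound 1; the two limits simply show that neither compound reached a measurable value.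

Compound 3, `COc1cc(C[C@@H]2C(=O)OC[C@H]2[C@@H](O)c2cc(OC)c(O[C@@H]3O[C@H](CO)[C@@H](O)[C@H](O)[C@H]3O)c(OC)c2)ccc1O`, differs from compound 2 in a single place: methoxy in place of hydrogen on an aromatic carbon. Going by the values given here, no measured pair of compounds shows what this kind of change does in this assay, so there is no measured step to lean on. With both measured compounds at the limit, the expectation for this assay is no step beyond the usual scatter, and most likely another limit rather than a number. The step that the limit leaves unreadable from compound 2 to compound 3 is expected to be small. Compound 3 is thus estimated at 20000 nM, with a range from 8000 nM to 60000 nM.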

Compound 3, half-maximal inhibitory concentration: > 10000 nM
Compound 3: no number, only a limit; the forecaster's own chance of this, stated with the estimate: 85%; the middle value is on the limit's open side.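

Compound 3 gives > 10000 nM in this assay, which is a limit and not a number. Compound 2 also stands at a limit, so no step can be read between compound 2 and compound 3, and all three compounds end alike: the limit of > 10000 nM in this assay, at which 3 of the 3 values shown sit.

The compounds shown leave open what methoxy in place of hydrogen on an aromatic carbon does, and how far any of them lies beyond the limit.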